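The source may report more compounds than this note shows. Statements on the series, on what has been measured and on what is new or still open speak of the compounds shown alone.

Compound 3 `COC(=O)/C=C/c1ccncc1-c1ccc2ccccc2c1` has the lower of the two numbers in a functional assay on MDA-MB-231 cells (Homo sapiens) for inhibition, read by sulforhodamine B assay, with a stated time of 72 h (a higher number here means a weaker inhibitor of growth, a lower number a stronger inhibitor of growth), where compound 3 gives 4710 nM. Its nearest neighbour is compound 1 `CCOC(=O)/C=C/c1ccncc1-c1ccc2c(ccn2C)c1`, which in this assay gives 10200 nM. Compound 2 `COC1CN(C(=O)/C=C/c2ccncc2-c2ccc3ccccc3c2)C1` in this assay returns only a limit, > 10000 nM. Among the compounds with values here, the single step between measured compounds that differ in one place, an at least 2.1-fold lower number from compound 2 to compound 3 (0.32 log units; beyond the scatter), is bounded by the limit of > 10000 nM in this assay, at which 1 of the 3 values shown sits, rather than by a second number.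

Compound 4 `NNC(=O)CCc1ccncc1-c1ccc2ccccc2c1` is not yet measured. It differs from compound 3 in one place: 2-(aminocarbamoyl)ethyl in place of 2-(methoxycarbonyl)ethenyl on an aromatic carbon. Within the data shown here, the only measured step touches the same group, where a methoxy in place of 3-methoxyazetidin-1-yl on the carbonyl carbon gave an at least 2.1-fold lower number from compound 2 to compound 3 (0.32 log units; beyond the scatter); it shows that what sits on the carbonyl carbon can move the number by a modest amount. Here the entire 2-(methoxycarbonyl)ethenyl leaves and 2-(aminocarbamoyl)ethyl enters, a broader change than the one measured, so a rise of the number is expected, with a fair chance that only a limit comes back. The expected step is a 1.9-fold higher number from compound 3 to compound 4 (0.28 log units; within the scatter). Compound 4 is therefore estimated at 9000 nM, within a range from 3000 nM to 27000 nM.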

Compound 4, concentration for 50% growth inhibition: > 10000 nM
Compound 4 was reported as a limit; the forecaster's own chance of this, stated with the estimate: 40%; middle value at least 1.1-fold (0.04 log units) from the limit.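

Putting 2-(aminocarbamoyl)ethyl in place of 2-(methoxycarbonyl)ethenyl on this aromatic carbon, opposite the ring nitrogen, gives an at least 2.1-fold higher number from compound 3 to compound 4 (0.32 log units; beyond the scatter) in this assay, so the number responds to a change of the whole group at this position and not only to what sits on the carbonyl carbon. Unlike the earlier step, which kept the ethenyl link, this change removes the chain's carbon-carbon double bond and brings in hydrogen-bond donors at the same time, and the result cannot separate these two differences. Compound 4, like compound 2, stands at a limit and not at a number, so only a lower bound on the step can be read: the limit of > 10000 nM in this assay, at which 2 of the 4 values shown sit.

Going by these compounds, it remains open what a 2-(methoxycarbonyl)ethyl or a 2-(aminocarbamoyl)ethenyl would give at this carbon, and so which part of the change carries the step. Also open, on these data alone, is how a carboxylic acid, a primary amide or a longer chain would compare with compound 3, which gives 4710 nM in this assay.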